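Swapping Chloro for Methoxy in Anti-Inflammatory Hydrazones

The source may hold more compounds than are shown below. What is called first, only, known or untested is meant among the compounds shown, and "the series" means these compounds.

Of the compounds shown here, three have been tested in a functional assay on the whole organism (strain Wistar) for inhibition, with Rattus norvegicus as the target, read by paw edema, with a stated time of 30 min, at a dose of 10 mg/kg by the intraperitoneal route; on this read-out lower numbers stand for less inhibition and higher numbers for more inhibition at the one dose given (going by the name of the read-out). Compound 1 `O=C(N/N=C/c1ccc(Cl)cc1)c1cccnc1Nc1cccc(C(F)(F)F)c1` and compound 2 `COc1ccc(/C=N/NC(=O)c2cccnc2Nc2cccc(C(F)(F)F)c2)cc1` share one core; the change between them is methoxy in place of chloro on an aromatic carbon. In this assay compound 1 gives 52.4% and compound 2 gives 50.4%, so the step of a number 2 percentage points lower from compound 1 to compound 2 (within the scatter) is too small to be read as a real change. Compound 3 `CNc1ncccc1C(=O)N/N=C/c1cccc(Cl)c1` is built on a different core; the difference between the two cores is not broken down here. In this assay compound 3 gives 67.1%, the highest of the three, and its gaps to compound 1 and compound 2 are both beyond the scatter.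

Compound 4 `CNc1ncccc1C(=O)N/N=C/c1cccc(OC)c1` has not been measured. It differs from compound 3 by methoxy in place of chloro on an aromatic carbon. The surroundings of the exchange differ from the earlier pair: there the methoxy entered para to a large group, here it enters meta to a large group, so this is the same kind of change rather than the same change. The step from compound 3 to compound 4 is expected to be about a number 2.1 percentage points lower from compound 3 to compound 4 (within the scatter), resting on the small step of a number 2 percentage points lower from compound 1 to compound 2 (within the scatter). Compound 4 is therefore estimated at 65%, with a likely range from 50% to 78%.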

Compound 4, a percentage reported as inhibition, in the whole organism at one dose (the size of the read-out at that dose, not a potency): 56.1%
For compound 4 the middle estimate is 8.9 percentage points above the measured one; low and high end bracket the measured number.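

In this assay, methoxy in place of chloro gives a number 11 percentage points lower from compound 3 to compound 4 (beyond the scatter), so on the core of compound 3 this exchange is followed by a drop larger than the usual scatter. Set beside the earlier pair, however, this step cannot be called different from the first, since the gap between the two is no larger than noise would allow: the same change on two cores in this assay, a number 2 percentage points lower (within the scatter) from compound 1 to compound 2 and a number 11 percentage points lower (beyond the scatter) from compound 3 to compound 4, 9 percentage points apart, within the scatter of two such steps The two pairs therefore do not show that the core alters the effect of this exchange, nor do they prove that the effect carries over unchanged, and the exchange also sits meta to a large group in compound 4 but elsewhere in the earlier pair, so core and placement cannot be separated.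

The compounds shown leave open how the chloro and methoxy groups would compare at a single matched place on both cores. They also leave open how an amine, a carboxylic acid or a longer chain such as ethoxy would fare in that same place.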